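Working notes on cytotoxicity across four related compounds

A few compounds are considered here, and "the series" means these few. Any claim that something is new, unique, unknown or untested is made for them only; others in the source may bear on it.

Compound 1 `O=C1c2ccccc2N(COCc2ccccc2)S(=O)(=O)N1Cc1ccccc1` is the starting point of the set. In a functional assay on HEL cells (Homo sapiens) for cytotoxicity (a lower number here means that less compound is tolerated, a higher number that more compound is tolerated), compound 1 gives > 50 ug/mL, which is a limit of the assay. Compound 2 `O=C1c2ccccc2N(COCCO)S(=O)(=O)N1Cc1ccccc1` carries hydroxymethyl in place of phenyl on a saturated chain carbon bound to an oxygen on a saturated carbon. In this assay compound 2 gives > 50 ug/mL, again a limit. The step that the two limits leave unreadable from compound 1 to compound 2 therefore cannot be sized. Compound 3 `O=C1NS(=O)(=O)N(COCc2ccccc2)c2ccccc21` differs from compound 1 by hydrogen in place of benzyl on an amide-type nitrogen in a ring. In this assay compound 3 gives > 50 ug/mL, also a limit. The step that the two limits leave unreadable from compound 1 to compound 3 is likewise not readable. All three measured values sit at the same limit (the limit of > 50 ug/mL in this assay, at which 3 of the 3 values shown sit).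

Compound 4 `O=C1NS(=O)(=O)N(COCCO)c2ccccc21` has not yet been measured. It differs from compound 3 by hydroxymethyl in place of phenyl on a saturated chain carbon bound to an oxygen on a saturated carbon, the same change as from compound 1 to compound 2, made in the same place on the core of compound 3. Compound 1 and compound 2 both rest at the limit (the limit of > 50 ug/mL in this assay, at which 3 of the 3 values shown sit). On that basis the step of a number no higher from compound 3 to compound 4 (the limit leaves the size open) in this assay is expected to be small. Compound 4 is expected to give about 50 ug/mL in this assay, with a likely span from 25 ug/mL to 100 ug/mL, and most probably to be reported only as a limit.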

Compound 4, minimum cytotoxic concentration: > 50 ug/mL
Compound 4: a limit, no number; the forecaster's own chance of this, stated with the estimate: 85%; the middle value sits exactly at the limit.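

In this assay compound 4 gives > 50 ug/mL, a limit and not a number. No step can be read from compound 3 to compound 4 or from compound 2 to compound 4, and the set rests at one value: the limit of > 50 ug/mL in this assay, at which 4 of the 4 values shown sit.

The compounds shown leave open at what concentration any of the four becomes cytotoxic, and whether benzyl to 2-hydroxyethyl or hydrogen in place of benzyl shifts that concentration.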